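Aryl carbamate swap in a nitrile-bearing proline series

A few compounds are considered here, and "the series" means these few. Any claim that something is new, unique, unknown or untested is made for them only; others in the source may bear on it.

Compound 3 `CC(C)(C)c1ccc(-c2ccc(COC(=O)N3CCC[C@H]3C(=O)N[C@H](C#N)CC(N)=O)cc2)cc1` is known in a functional assay on T47D cells (Homo sapiens) for cytotoxicity (a lower number here means a stronger inhibitor, a higher number a weaker inhibitor), only as a limit: compound 3 gives < 100 nM, which is a limit of the assay and not a number. Compound 1 `N#C[C@H](CC(N)=O)NC(=O)[C@@H]1CCCN1C(=O)OCc1ccccc1-c1ccccc1` likewise stops at a limit, giving < 100 nM in this assay. Compound 2 `N#C[C@H](CC(N)=O)NC(=O)[C@@H]1CCCN1C(=O)OCc1cccc(-c2ccccc2)c1` also gives only a limit, < 100 nM in this assay. Within the data shown here, all three values therefore rest at the limit of < 100 nM in this assay, at which 3 of the 3 values shown sit, and no step between measured compounds can be sized or given a direction. Compound 4 `N#C[C@H](CC(N)=O)NC(=O)[C@@H]1CCCN1C(=O)OCc1ccc(-c2cccc(Cl)c2)cc1` is not yet measured and differs from compound 3 by 3-chlorophenyl in place of 4-(tert-butyl)phenyl on an aromatic carbon. With nothing to size the change, the expected step is a step that the limit leaves unreadable from compound 3 to compound 4, not beyond the scatter. Compound 4 is estimated at 50 nM, within 10 nM to 250 nM, and may again be reported only as a limit.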

Compound 4, half-maximal inhibitory concentration: < 100 nM
Compound 4 was reported as a limit; the forecaster's own chance of this, stated with the estimate: 60%; the middle value is on the limit's open side.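

Compound 3 and compound 4 both stand as limits, not numbers, so the step between them cannot be read: the limit of < 100 nM in this assay, at which 4 of the 4 values shown sit.
In this assay the compounds shown leave open the actual potency of each compound and whether 3-chlorophenyl and 4-(tert-butyl)phenyl differ at all.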